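A few compounds are considered here, and "the series" means these few. Any claim that something is new, unique, unknown or untested is made for them only; others in the source may bear on it.

Values in a functional assay on Caco-2 cells (Homo sapiens), read by MTT assay, with a stated time of 48 h; a higher number here means a weaker inhibitor, a lower number a stronger inhibitor:
- compound 1 `CCn1c(C(=O)NCCN(C)C)ccc1C(CC)(CC)c1ccc(OCC(O)C(C)(C)C)c(C)c1`: 1300 nM
- compound 2 `CCn1c(C(=O)NCCCN(C)C)ccc1C(CC)(CC)c1ccc(OCC(O)C(C)(C)C)c(C)c1`: 1900 nM

Within the data shown here, compound 2 stands at 1900 nM, within the scatter of compound 1, the only other measured member of the series. The next compound to be measured is compound 3 `CCN(CC)CCCNC(=O)c1ccc(C(CC)(CC)c2ccc(OCC(O)C(C)(C)C)c(C)c2)n1CC`. Its difference from compound 2 is diethylamino in place of dimethylamino on a saturated chain carbon, three bonds along the chain from an amide-type nitrogen.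

Among the measured compounds shown here, only one measured step bears on this, and only indirectly, since it changes the chain and not the amine: a 1.5-fold higher number from compound 1 to compound 2 (0.16 log units; within the scatter). For the measured compounds named here, no measured step tests the diethylamino group itself. With that single guide, no shift beyond the scatter is expected in this assay. The expected step is a 1.1-fold lower number from compound 2 to compound 3 (0.05 log units; within the scatter). The estimate for compound 3 is 1700 nM, with an expected range of 750 nM to 3800 nM.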

Compound 3, half-maximal inhibitory concentration: 1800 nM
The estimate for compound 3 lay 1.1-fold (0.02 log units) below the measured number; low and high end bracket the measured number.
By their numbers in this assay, from the lowest: compounds 1, 3 and 2 (each within the scatter of the next).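

In this assay, among these compounds, the first reading on the amine substituents themselves, 3-(diethylamino)propyl in place of 3-(dimethylamino)propyl, gives a 1.1-fold lower number from compound 2 to compound 3 (0.02 log units; within the scatter), so this exchange at the chain end does not separate the two compounds. The chain extension and the amine exchange taken together give a 1.4-fold higher number from compound 1 to compound 3 (0.14 log units; within the scatter), which also leaves all three compounds within the scatter of one another. No supporting evidence bears on why the numbers stay so close.

As far as these compounds go, whether a ring amine such as piperidine or morpholine at the chain end, or a longer butyl chain, would move the number beyond the scatter remains open. Also open, from the compounds shown here alone, is what the terminal amine contributes, since all three compounds carry one and a neutral end group such as a methoxy group or a hydroxyl group would be needed to test it.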